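This account rests on a few compounds, and the source may have more. Where it says the series, first, only, none or still open, it means among the compounds named here.

Measured compounds:
Compound 1, `Cc1ccc(C(=O)NNC(=S)Nc2csc(-c3ccccc3)c2)cc1`, with 24000 nM in a functional assay on B16-F10 cells (Mus musculus) for inhibition, read by colorimetric assay and MTT assay, with a stated time of 72 h; a higher number here means a weaker inhibitor, a lower number a stronger inhibitor.
Compound 2, `COc1ccc(C(=O)NNC(=S)Nc2csc(-c3ccccc3)c2)cc1OC`, with 9000 nM in this assay.
Compound 3, `COc1ccc(-c2cc(Nc3nnc(-c4ccc(C)cc4)s3)cs2)cc1`, with "not determined" (no result reported) in this assay.

In this assay, for the measured compounds named here, compound 1 gives 24000 nM and compound 2 gives 9000 nM; both share a core that differs from the one in compound 3. Compound 3 stands nowhere on the numbers: for it this assay returned no single value, so there is no measured point from which a step to compound 4 could be counted.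

Compound 4, `Cc1ccc(-c2nnc(Nc3csc(-c4ccccc4)c3)s2)cc1`, differs from compound 3 by hydrogen in place of methoxy on an aromatic carbon, the same difference read one bond further out being 4-methoxyphenyl to phenyl. With compound 3 unmeasured, no direction for this step can be read from the data; the expectation for compound 4 rests only on the values of compound 1 and compound 2, which lie in the same broad region.

Compound 4 is therefore expected to give about 15000 nM in this assay, estimated to fall between 4000 nM and 60000 nM.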

Compound 4, half-maximal inhibitory concentration: 4000 nM
Compound 4: middle estimate off by 3.8-fold (0.57 log units), on the high side, and the stated range covers the measured number.
By their numbers in this assay, from the lowest: compound 4; then compound 2; then compound 1.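

In this assay, for the compounds shown here, compound 4 gives 4000 nM while compound 3 has no single value, so no step between compound 3 and compound 4 can be read. The compounds shown leave open what exchanging methoxy for hydrogen does here. No supporting evidence bears on this result.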